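The source may report more compounds than this note shows. Statements on the series, on what has been measured and on what is new or still open speak of the compounds shown alone.

Measured so far, in a functional assay on MOLT-4 cells (Homo sapiens) for inhibition, read by sulforhodamine B assay, with a stated time of 48 h, tested at 10 uM; a higher number here means more inhibition at the concentration tested (going by the name of the read-out), a lower number less inhibition:
Compound 1 `Brc1cn2ccnc2c(-c2ccc3ncn(C4CCCCC4)c3c2)n1` gives 26.3%.
Compound 2 `c1ccc(-c2cn3ccnc3c(-c3ccc4ncn(C5CCCCC5)c4c3)n2)cc1` gives 67.7%.
Compound 3 `COc1ccc(-c2cn3ccnc3c(-c3ccc4ncn(C5CCCCC5)c4c3)n2)cc1` gives 82.8%.

Compound 3 stands highest of the three numbers, and its distance to each of the other two is beyond the scatter of repeated measurements. Two large steps, a number 41.4 percentage points higher from compound 1 to compound 2 (beyond the scatter) and a number 56.5 percentage points higher from compound 1 to compound 3 (beyond the scatter), show that putting an aromatic ring in place of the bromo lifts inhibition a great deal. The smaller step of a number 15.1 percentage points higher from compound 2 to compound 3 (beyond the scatter) shows that the methoxy on that ring adds a modest further gain on top of the ring itself.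

Compound 4 `O=Cc1ccc(-c2cn3ccnc3c(-c3ccc4ncn(C5CCCCC5)c4c3)n2)cc1` differs from compound 3 in one place: formyl in place of methoxy on an aromatic carbon. For the measured compounds named here, no measured step exchanges one small group on this ring for another; the only step that touches this carbon is a number 15.1 percentage points higher from compound 2 to compound 3 (beyond the scatter), which tells how much the methoxy itself is worth. The formyl is of similar size and also carries one hydrogen-bond acceptor, so the most that can be said is that compound 4 should keep most of what the ring brings and lie close to compound 3, with a modest drop toward compound 2 as the likeliest outcome. Compound 4 is therefore expected at 72%, within 50% to 88%. This estimate means a step of a number 10.8 percentage points lower from compound 3 to compound 4 (beyond the scatter), expected to sit near the edge of the scatter.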

Compound 4, a percentage reported as inhibition, at one concentration (the size of the read-out at that concentration, not a potency): 58.7%
Compound 4: middle estimate off by 13.3 percentage points, on the high side, within the range that was stated.
By their numbers in this assay, from the lowest: compound 1; then compounds 4 and 2 (each within the scatter of the next); then compound 3.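

In this assay, formyl and methoxy match in their counts of heavy atoms and hydrogen-bond acceptors, yet exchanging them gives a number 24.1 percentage points lower from compound 3 to compound 4 (beyond the scatter), so at this carbon those counts alone do not settle the outcome. The step from the bare phenyl to the formyl-bearing ring, a number 9 percentage points lower from compound 2 to compound 4 (within the scatter), cannot be told apart from no change, which shows that the gain seen with methoxy does not come with every small group placed on this carbon. The 4-formylphenyl group still stands well clear of the bromo, with a number 32.4 percentage points higher from compound 1 to compound 4 (beyond the scatter), so much of the lift from adding the aromatic ring survives with formyl on it.

No measurement shown here accounts for the difference between methoxy and formyl at this carbon. On these data alone, it also remains open whether an amine, a carboxylic acid or a longer chain such as ethoxy on this carbon would give a number level with compound 3, level with compound 4, or different from both.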